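The source may hold more compounds than are shown below. What is called first, only, known or untested is meant among the compounds shown, and "the series" means these compounds.

Measured so far in a functional assay on MCF7 cells (Homo sapiens) for antiproliferative activity, read by MTT assay, with a stated time of 24 h; on this read-out higher numbers stand for weaker inhibition and lower numbers for stronger inhibition:
compound 1 `Brc1ccc(Cc2nnc(Cn3nnc4ccccc43)o2)cc1` gives 277000 nM
compound 2 `Fc1cccc(Cc2nnc(Cn3nnc4ccccc43)o2)c1` gives 357000 nM
compound 3 `COc1cccc(Cc2nnc(Cn3nnc4ccccc43)o2)c1` gives 241000 nM

Compound 1 cannot be told apart from the other two. For the measured compounds named here, the data show a 1.3-fold higher number from compound 1 to compound 2 (0.11 log units; within the scatter) and a 1.1-fold lower number from compound 1 to compound 3 (0.06 log units; within the scatter) in the same breath, so it sits inside a tight group and no member of the group stands clear of the rest.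

The next compound is compound 4 `COc1ccc(Cc2nnc(Cn3nnc4ccccc43)o2)cc1`, where 4-bromophenyl gives way to 4-methoxyphenyl. This is methoxy in place of bromo on an aromatic carbon, para to a large group: methoxy in place of bromo on an aromatic carbon for the whole exchange.

Going by the values given here, no measured pair holds exactly this exchange. The nearest is the move to 3-methoxyphenyl, with a 1.1-fold lower number from compound 1 to compound 3 (0.06 log units; within the scatter) as its result. Methoxy in place of fluoro, on compounds with the group elsewhere on the ring, gave a 1.5-fold lower number from compound 2 to compound 3 (0.17 log units; within the scatter) as its result. Neither step leaves the scatter, so no step beyond the scatter is expected in this assay here. The estimated outcome is a 1.1-fold lower number from compound 1 to compound 4 (0.03 log units; within the scatter) and would leave compound 4 within the same group. The estimate for compound 4 is 260000 nM with 140000 nM to 480000 nM as its expected range.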

Compound 4, half-maximal inhibitory concentration: 251000 nM
The estimate for compound 4 lay 1.0-fold (0.02 log units) above the measured number; low and high end bracket the measured number.
By their numbers in this assay, from the lowest: compounds 3, 4, 1 and 2 (each within the scatter of the next).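

At the aromatic carbon para to a large group, methoxy in place of bromo brings no readable change in this assay (a 1.1-fold lower number from compound 1 to compound 4 (0.04 log units; within the scatter)), even though 2 heavy atoms and 1 hydrogen-bond acceptor enter where 1 heavy atom and no acceptor leave. For the compounds shown here, the methoxy group can now be compared on the two ring positions for the first time, and 4-methoxyphenyl in place of 3-methoxyphenyl also separates nothing (a 1.0-fold higher number from compound 3 to compound 4 (0.02 log units; within the scatter)), while 4-methoxyphenyl in place of 3-fluorophenyl likewise stays inside the scatter (a 1.4-fold lower number from compound 2 to compound 4 (0.15 log units; within the scatter)). All four compounds therefore remain one group in this assay, and no measurement at hand explains why these exchanges leave the number in place.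

The compounds shown leave open whether any group on this aromatic carbon can move the number beyond the scatter, since bromo and methoxy are the only two compared there. An amine or a carboxylic acid at that place, or a longer chain in place of the saturated chain carbon that carries the ring, would test whether this part of the molecule matters in this assay at all.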